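Naphthyl for Cyclohexylmethyl: Expected Solubility of Compound 3

The compounds below may be only part of what the source reports. "The series", "measured", "known", "first", "only" and "open" are said of these compounds alone.

Compound 2 `COc1ccc(F)cc1CNCCCNc1ccnc2cc(CC3CCCCC3)ccc12` gives 4200 nM in a physicochemical assay for solubility, with a stated time of 18 h, at pH 7.4 (a higher number here means a more soluble compound, a lower number a less soluble compound), level with compound 1 `CCC(CC)c1ccc2c(NCCCNCc3cc(F)ccc3OC)ccnc2c1`, which gives 4200 nM. For the measured compounds named here, the one measured step, no change at the digits printed from compound 1 to compound 2 (within the scatter), swapped one group for another without a change beyond the scatter. Compound 3 `COc1ccc(F)cc1CNCCCNc1ccnc2cc(-c3cccc4ccccc34)ccc12` carries naphthalen-1-yl in place of cyclohexylmethyl on an aromatic carbon. Going by the values given here, no measured step covers a change of this kind, in which two aromatic rings enter where one non-aromatic ring left. Among the compounds with values here, the earlier swap is the only guide, and it was flat. A modest fall in this assay is nonetheless expected, a 2.8-fold lower number from compound 2 to compound 3 (0.45 log units; beyond the scatter). Compound 3 is estimated at 1500 nM, within 400 nM to 5000 nM.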

Compound 3, solubility: 32000 nM
Beside the measured number, compound 3's estimate is 21-fold (1.33 log units) below it; measured number outside the range, above it.
By their numbers in this assay, from the lowest: compounds 1 and 2 (each within the scatter of the next); then compound 3.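

In this assay this position on the shared core proves responsive, with a 7.6-fold higher number from compound 2 to compound 3 (0.88 log units; beyond the scatter) when naphthalen-1-yl replaces cyclohexylmethyl and a 7.6-fold higher number from compound 1 to compound 3 (0.88 log units; beyond the scatter) when it replaces pentan-3-yl. The flat earlier swap between two non-aromatic groups therefore did not mean that every group gives the same number here, and the number rose even though the entering group has more heavy atoms. Nothing among the data shown explains this rise. On these data alone, whether a single phenyl ring or naphthalen-2-yl would give a similar rise remains open, as does the effect of an amine at this aromatic carbon.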